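From 2,6-dichlorobenzyl to benzyl: a small step expected

A few compounds are considered here, and "the series" means these few. Any claim that something is new, unique, unknown or untested is made for them only; others in the source may bear on it.

In a functional assay on CNE2Z cells (Homo sapiens) for inhibition, read by MTT assay, with a stated time of 72 h (on this read-out lower numbers stand for stronger inhibition and higher numbers for weaker inhibition), compound 2 `C=CCc1ccc(OCc2c(Cl)cccc2Cl)c(-c2ccc(O)c(CC=C)c2)c1` gives 19900 nM and compound 1 `C=CCc1ccc(OCc2ccc(Cl)c(Cl)c2)c(-c2ccc(O)c(CC=C)c2)c1` gives 14200 nM, so the two stand level within the usual scatter. Compound 3 `C=CCc1ccc(OCc2ccccc2)c(-c2ccc(O)c(CC=C)c2)c1` has phenyl in place of 2,6-dichlorophenyl on a saturated chain carbon bound to an oxygen on an aromatic ring. Within the data shown here, the only measured step at this place is a 1.4-fold higher number from compound 1 to compound 2 (0.15 log units; within the scatter), an exchange of dichlorophenyl groups, and no measured compound lacks the chlorines. No change beyond the scatter is therefore expected in this assay. The expected step is a 1.0-fold higher number from compound 2 to compound 3 (0.00 log units; within the scatter). For compound 3 the estimate is 20000 nM, with an expected range of 9000 nM to 45000 nM.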

Compound 3, half-maximal inhibitory concentration: 24000 nM
Beside the measured number, compound 3's estimate is 1.2-fold (0.08 log units) below it; the measured number falls inside the stated range.
By their numbers in this assay, from the lowest: compounds 1, 2 and 3 (each within the scatter of the next).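

In this assay, among these compounds, compound 3 is the first compound here with no chlorine on this ring, and phenyl in place of either dichlorophenyl group gives a 1.2-fold higher number from compound 2 to compound 3 (0.08 log units; within the scatter) and a 1.7-fold higher number from compound 1 to compound 3 (0.23 log units; within the scatter), both small enough to read as no real difference. On a saturated chain carbon bound to an oxygen on an aromatic ring, these compounds therefore show no sign that the chlorines matter. Nothing available explains this result.

All three compounds keep a plain or chlorinated phenyl at this place. As far as these compounds go, whether an amine or a carboxylic acid on that ring, or a longer chain before it, would shift the number remains open.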